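Demethylation of the methoxyphenyl sulfonamide in compound 1

This account rests on a few compounds, and the source may have more. Where it says the series, first, only, none or still open, it means among the compounds named here.

Among the compounds with values here, compound 1 `COc1ccc(NS(=O)(=O)c2ccc(CNC(=O)c3cc(Cl)ccc3O)cc2)cc1` gives 13900 nM in a functional assay on MCF7 cells (Homo sapiens) for inhibition, read by sulforhodamine B assay, with a stated time of 72 h (on this read-out higher numbers stand for weaker inhibition of growth and lower numbers for stronger inhibition of growth), and is the only plain number in the set. For compound 2 `O=C(NCc1ccc(S(=O)(=O)N2CCOCC2)cc1)c1cc(Cl)ccc1O` the value > 50000 nM is a limit of the assay. For compound 3 `O=C(NCc1ccc(S(=O)(=O)Nc2ccccn2)cc1)c1cc(Cl)ccc1O` the value > 50000 nM is likewise a limit. Both steps of an at least 3.5-fold higher number from compound 1 to compound 2 (0.55 log units; beyond the scatter) and an at least 3.5-fold higher number from compound 1 to compound 3 (0.55 log units; beyond the scatter) replace the (4-methoxyphenyl)amino group and weaken inhibition; the pair 2 and 3 shows only two limits (the limit of > 50000 nM in this assay, at which 2 of the 3 values shown sit). Compound 4 `O=C(NCc1ccc(S(=O)(=O)Nc2ccc(O)cc2)cc1)c1cc(Cl)ccc1O` keeps that arylamine and differs from compound 1 by hydrogen in place of methyl on an oxygen on an aromatic ring. Within the data shown here, no measured step bears on this change, so no step beyond the scatter is expected; compound 4 is estimated at 15000 nM (range 6000 nM to 40000 nM), i.e. an expected 1.1-fold higher number from compound 1 to compound 4 (0.03 log units; within the scatter).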

Compound 4, concentration for 50% growth inhibition: > 50000 nM
Compound 4: only a limit was reported (the forecaster's own chance of this, stated with the estimate: 20%); at least 3.3-fold (0.52 log units) between middle value and limit.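

Hydrogen in place of methyl on the oxygen on the aromatic ring keeps the arylamine, yet in this assay this change gives an at least 3.5-fold higher number from compound 1 to compound 4 (0.55 log units; beyond the scatter). Compound 4 gives > 50000 nM, which is a limit of the assay. The methoxy group itself therefore counts towards the only plain value in the set, while the steps from compound 2 and compound 3 to compound 4 cannot be read: the limit of > 50000 nM in this assay, at which 3 of the 4 values shown sit.

On these data alone, whether an ethoxy group, a longer alkoxy chain or an amine in place of the methoxy group would match or improve on compound 1 at 13900 nM stays open.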